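A few compounds are considered here, and "the series" means these few. Any claim that something is new, unique, unknown or untested is made for them only; others in the source may bear on it.

Measured in a functional assay on L1210 cells (Mus musculus) for inhibition, read by cell counting, with a stated time of 2 days; on this read-out lower numbers stand for stronger inhibition and higher numbers for weaker inhibition: compound 1 `C=C(Br)C(=O)Nc1cccc(-c2cn3nc(-c4ccc(CC)cc4)sc3n2)c1` gives 2200 nM; compound 2 `C=C(Br)C(=O)Nc1cccc(-c2cn3nc(-c4ccccc4)sc3n2)c1` gives 600 nM; compound 3 `Nc1cccc(-c2cn3nc(Cc4ccc(Cl)cc4)sc3n2)c1` gives 16000 nM.

Compound 2 has the lowest number of the three; the nearest step is a 3.7-fold lower number from compound 1 to compound 2 (0.56 log units; beyond the scatter), and compound 3 lies considerably further off. Compound 4 `C=C(Br)C(=O)Nc1cccc(-c2cn3nc(-c4cccc(OC)c4)sc3n2)c1` differs from compound 2 by methoxy in place of hydrogen on an aromatic carbon, the group entering meta to a large group, so the pendant ring reads phenyl to 3-methoxyphenyl. For the measured compounds named here, one measured step bears on substitution of this ring: a 3.7-fold lower number from compound 1 to compound 2 (0.56 log units; beyond the scatter), where removal of ethyl lowered the number modestly. Methoxy adds 2 heavy atoms to the same ring, so a small move toward higher numbers, near the scatter, is expected. Compound 4 is expected to give 900 nM (range 350 nM to 2500 nM) in this assay. This estimate means a step of a 1.5-fold higher number from compound 2 to compound 4 (0.18 log units; within the scatter).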

Compound 4, half-maximal inhibitory concentration: 580 nM
Compound 4: the middle estimate sits 1.6-fold (0.19 log units) above what was measured; low and high end bracket the measured number.
By their numbers in this assay, from the lowest: compounds 4 and 2 (each within the scatter of the next); then compound 1; then compound 3.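

Methoxy meta to a large group leaves the number in this assay unmoved within the scatter: a 1.0-fold lower number from compound 2 to compound 4 (0.01 log units; within the scatter). Substitution on this ring therefore does not by itself go with a higher number, and compound 1 is the case that does, with a 3.8-fold lower number from compound 1 to compound 4 (0.58 log units; beyond the scatter). Nothing at hand explains why these two substituted rings differ. Open, on these data alone, is whether ethyl in this same place would match methoxy, which would separate the group from its place on the ring. Also open, as far as these compounds go, is how an amine or a carboxylic acid would read here.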